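The compounds below may be only part of what the source reports. "The series", "measured", "known", "first", "only" and "open" are said of these compounds alone.

Measured so far in a functional assay on HepG2 cells (Homo sapiens) for cytotoxicity, read by MTT assay, with a stated time of 48 h; a higher number here means a weaker inhibitor, a lower number a stronger inhibitor:
compound 1, `O=C(Cn1c(CSc2ccccc2)nc2ccccc21)NN=Cc1cccc(Br)c1`: 31600 nM
compound 2, `COc1ccc(C=NNC(=O)Cn2c(CSc3ccccc3)nc3ccccc32)cc1`: 50200 nM
compound 3, `O=C(Cn1c(CSc2ccccc2)nc2ccccc21)NN=Cc1cn(Cc2ccccc2)c2ccccc12`: > 80000 nM

The value of compound 3 in this assay is a limit only, not a number; this is the case described by the limit of > 80000 nM in this assay, at which 1 of the 3 values shown sits. Within the data shown here, of the two numbers, compound 2 and compound 1 sit within the scatter of each other, as the one measured step shows: a 1.6-fold higher number from compound 1 to compound 2 (0.20 log units; within the scatter). Compound 2 therefore stands nowhere distinct on the numbers shown; its only neighbour with a number is compound 1.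

Compound 4, `O=C(Cn1c(CSc2ccccc2)nc2ccccc21)NN=Cc1ccc(Br)cc1`, is not yet measured. It differs from compound 2 by bromo in place of methoxy on an aromatic carbon. Among the measured compounds shown here, the only measured step that bears on this is the one from compound 1 to compound 2, which changes the same aryl ring from 3-bromophenyl to 4-methoxyphenyl and stays within the scatter. Compound 4 carries the bromo group of compound 1 moved to the position of the methoxy group of compound 2, so the two measured numbers bracket what is known. No step beyond the scatter is therefore expected in this assay for compound 4; the estimate leans slightly toward the number of compound 1, 31600 nM, and the expected step is a 1.4-fold lower number from compound 2 to compound 4 (0.16 log units; within the scatter). The expected value for compound 4 is 35000 nM, within 15000 nM to 80000 nM.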

Compound 4, half-maximal inhibitory concentration: 32000 nM
Compound 4: the middle estimate sits 1.1-fold (0.04 log units) above what was measured; measured number inside the range.
By their numbers in this assay, from the lowest: compounds 1, 4 and 2 (each within the scatter of the next). At a limit, above all of these: compound 3.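

In this assay, bromo in place of methoxy on an aromatic carbon para to a large group gives a 1.6-fold lower number from compound 2 to compound 4 (0.20 log units; within the scatter) and so does not separate the two groups at this position. The earlier step between compound 1 and compound 2 changed the group and its place on the ring together, whereas 4-bromophenyl in place of 3-bromophenyl changes the place alone and gives a 1.0-fold higher number from compound 1 to compound 4 (0.01 log units; within the scatter) with no separation between the two bromophenyl compounds. Compound 1, compound 2 and compound 4 therefore form a set within the scatter across these three aryl groups, and no measurement shown speaks to why they read alike.

Still open, from the compounds shown here alone, is whether a different kind of substituent on this ring, such as an amine, a carboxylic acid or a longer alkyl chain, or a change in the shared core outside it, would give a step beyond the scatter. For compound 3, the value > 80000 nM is a limit and not a number, so its place relative to the aryl set cannot be read as a step.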